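This account rests on a few compounds, and the source may have more. Where it says the series, first, only, none or still open, it means among the compounds named here.

Measured so far in a functional assay on A-375 cells (Homo sapiens) for cytotoxicity, read by MTT assay; a lower number here means a stronger inhibitor, a higher number a weaker inhibitor:
- compound 1 `O=C(NCCNc1nccc(-c2c(-c3cccc(F)c3)nc3sccn23)n1)c1c(F)cccc1F`, compound 1 gives 2700 nM
- compound 2 `Cc1ccc(S(=O)(=O)NCCNc2nccc(-c3c(-c4cccc(F)c4)nc4sccn34)n2)cc1`, compound 2 gives 15400 nM
- compound 3 `O=C(NCCNc1nccc(-c2c(-c3cccc(F)c3)nc3sccn23)n1)c1ccc(C(F)(F)F)cc1`, compound 3 gives 8710 nM

Compound 2 holds the highest of the three numbers. Its nearest neighbour is compound 3, a 1.8-fold lower number from compound 2 to compound 3 (0.25 log units; within the scatter), which is within the scatter; the gap to compound 1 is wider, a 5.7-fold higher number from compound 1 to compound 2 (0.76 log units; beyond the scatter), and lies beyond it. The same carbonyl-for-sulfonyl comparison, seen against a different aryl group, is a 3.2-fold higher number from compound 1 to compound 3 (0.51 log units; beyond the scatter).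

Compound 4 `O=C(NCCCNc1nccc(-c2c(-c3cccc(F)c3)nc3sccn23)n1)c1ccc(F)cc1` is the next member to be run in this assay. Relative to compound 2 the change is (((4-fluorophenyl)carbonyl)amino)methyl in place of ((4-methylphenyl)sulfonyl)amino on a saturated chain carbon, two bonds along the chain from a nitrogen on an aromatic ring. Two of the measured steps speak to this change: the move from sulfonyl to carbonyl is the step from compound 2 to compound 1, and also from compound 2 to compound 3, and both point toward a lower number, one beyond the scatter and one within it. Within the data shown here, the extra chain carbon has no measured counterpart in this set, and the 4-fluorophenyl group is likewise untested here, so those parts of the change cannot be weighed.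

On the balance of the two carbonyl-bearing comparisons, compound 4 is expected to give a lower number than compound 2, the expected step being a 2.8-fold lower number from compound 2 to compound 4 (0.45 log units; beyond the scatter). The estimate for compound 4 in this assay is 5500 nM, with a range from 1800 nM to 17000 nM.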

Compound 4, half-maximal inhibitory concentration: 14900 nM
Compound 4: the middle estimate sits 2.7-fold (0.43 log units) below what was measured, and the stated range covers the measured number.
By their numbers in this assay, from the lowest: compound 1; then compounds 3, 4 and 2 (each within the scatter of the next).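

In this assay, placing (((4-fluorophenyl)carbonyl)amino)methyl in place of ((4-methylphenyl)sulfonyl)amino on this saturated chain carbon gives a 1.0-fold lower number from compound 2 to compound 4 (0.01 log units; within the scatter), so a carbonyl in place of a sulfonyl does not go with a lower number in every compound shown, and compound 4 is the case against that reading. Among these compounds, the comparison among carbonyl compounds gives a 5.5-fold higher number from compound 1 to compound 4 (0.74 log units; beyond the scatter), which leaves compound 1, with its ((2,6-difluorophenyl)carbonyl)amino group, as the only compound set apart from the rest, while compound 3 and compound 4, both carbonyl compounds, go against any pattern that credits the carbonyl alone. Nothing available here accounts for these numbers.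

Compound 4 alters the chain and the aryl group together, so the compounds shown cannot tell how much of the step belongs to each, nor whether the 2,6-difluorophenyl carbonyl on the (carbonyl)amino)methyl chain would keep the number of compound 1. Also open is how a longer chain, a free amine or a carboxylic acid at this position would read in this assay.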